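The compounds below may be only part of what the source reports. "The series", "measured", "known", "first", "only" and "open" are said of these compounds alone.

In a functional assay on A-375 cells (Homo sapiens) for antiproliferative activity, read by MTT assay, with a stated time of 48 h (on this read-out higher numbers stand for weaker inhibition of growth and lower numbers for stronger inhibition of growth), compound 3 `O=[N+]([O-])c1ccc(C2=NN(C(=S)Nc3ccccc3)C(c3ccc4c(c3)OCCO4)C2)cc1` gives 78100 nM, the highest of the three numbers measured. Compound 1 `S=C(Nc1ccccc1)N1N=C(c2ccccc2)CC1c1ccc2c(c1)OCCO2` gives 1850 nM and compound 2 `S=C(Nc1ccccc1)N1N=C(c2ccc(Br)cc2)CC1c1ccc2c(c1)OCCO2` gives 470 nM, and compound 3 stands beyond the scatter from both, as the steps of a 42-fold higher number from compound 1 to compound 3 (1.63 log units; beyond the scatter) and a 170-fold higher number from compound 2 to compound 3 (2.22 log units; beyond the scatter) show. Compound 4 `S=C(Nc1ccccc1)N1N=C(c2ccccc2Br)CC1c1ccc2c(c1)OCCO2` differs from compound 3 by 2-bromophenyl in place of 4-nitrophenyl on a carbon with a double bond to nitrogen. For the measured compounds named here, two measured steps bear on this change: the nitro group is removed, which reverses the large step of a 42-fold higher number from compound 1 to compound 3 (1.63 log units; beyond the scatter), and bromine is added, though as a 2-bromophenyl rather than the 4-bromophenyl of the modest step of a 3.9-fold lower number from compound 1 to compound 2 (0.60 log units; beyond the scatter). Going by the values given here, a large fall in this assay is therefore expected, close to the reversal of the nitro step; the bromine in a 2-bromophenyl has no measured counterpart. Compound 4 is estimated at 1500 nM, with a range from 400 nM to 6000 nM. This estimate means an expected step of a 52-fold lower number from compound 3 to compound 4 (1.72 log units; beyond the scatter).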

Compound 4, concentration for 50% growth inhibition: > 200000 nM
Compound 4 gave a limit, no number (the forecaster's own chance of this, stated with the estimate: 3%); middle value at least 130-fold (2.12 log units) away from the limit.
By their numbers in this assay, from the lowest: compound 2; then compound 1; then compound 3. At a limit, above all of these: compound 4.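

In this assay compound 4 gives a limit, not a number: the limit of > 200000 nM in this assay, at which 1 of the 4 values shown sits. Moving the bromine from 4-bromophenyl to 2-bromophenyl is a large change, an at least 420-fold higher number from compound 2 to compound 4 (2.62 log units; beyond the scatter), so where the bromine sits on the phenyl ring matters, not only whether it is present. As 2-bromophenyl, bromine acts in the opposite direction to 4-bromophenyl, with an at least 100-fold higher number from compound 1 to compound 4 (2.03 log units; beyond the scatter), and exchanging 4-nitrophenyl for 2-bromophenyl gives an at least 2.5-fold higher number from compound 3 to compound 4 (0.40 log units; beyond the scatter).

As far as these compounds go, it remains open whether a 2-chlorophenyl or 2-methylphenyl group would follow 2-bromophenyl. A 2-aminophenyl group at this carbon is equally untested here.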